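The source may report more compounds than this note shows. Statements on the series, on what has been measured and on what is new or still open speak of the compounds shown alone.

Compound 1 `O=C1/C(=C/c2ccccc2)Cc2cc(O)ccc21`: 376 nM
Compound 2 `O=C1/C(=C/c2ccccc2)Cc2ccc(O)cc21`: 2420 nM
Compound 3 `O=C1/C(=C/c2ccc(F)cc2)Cc2cc(O)ccc21`: 47 nM

In an assay on isolated protein for inhibition of Amine oxidase [flavin-containing] B (Homo sapiens), read by fluorescence and spectrophotometry, with a stated time of 20 min (a lower number here means a stronger inhibitor, a higher number a weaker inhibitor), compound 3 gives the lowest number of the three; compound 1 is nearest, compound 2 furthest, both beyond the scatter. Compound 4 `N#Cc1ccc(/C=C2\Cc3cc(O)ccc3C2=O)cc1` differs from compound 3 by cyano in place of fluoro on an aromatic carbon. Among the compounds with values here, the only measured step on this ring is an 8.0-fold lower number from compound 1 to compound 3 (0.90 log units; beyond the scatter), which concerns fluoro in place of hydrogen and does not speak directly to cyano in place of fluoro; no measured compound carries a cyano group. Going by these compounds, a substituent on this aromatic carbon has so far lowered the number, but the size for cyano is unknown, so a step near the scatter is the working assumption. Compound 4 is expected at 80 nM, between 20 nM and 320 nM. The expected step is a 1.7-fold higher number from compound 3 to compound 4 (0.23 log units; within the scatter).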

Compound 4, half-maximal inhibitory concentration: 316 nM
Beside the measured number, compound 4's estimate is 4.0-fold (0.60 log units) below it; the measured number falls inside the stated range.
By their numbers in this assay, from the lowest: compound 3; then compounds 4 and 1 (each within the scatter of the next); then compound 2.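

In this assay, the identity of the group on this aromatic carbon, para to a large group, decides the outcome: cyano in place of fluoro gives a 6.7-fold higher number from compound 3 to compound 4 (0.83 log units; beyond the scatter) and shows that a substituent here does not lower the number by its presence alone. Cyano in place of hydrogen gives a 1.2-fold lower number from compound 1 to compound 4 (0.08 log units; within the scatter) and leaves compound 4 level with the unsubstituted compound 1, so of the two groups shown only fluoro separates from hydrogen at this place. Nothing available on these compounds accounts for the difference between fluoro and cyano.

Still open, going by these compounds, is how chloro, methoxy or an amine would read at this place. Also open, on these data alone, is whether fluoro in place of hydrogen would carry over to the core of compound 2.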